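The source may report more compounds than this note shows. Statements on the series, on what has been measured and on what is new or still open speak of the compounds shown alone.

The compounds measured in an ADME assay on PC-3 cells (Homo sapiens) for cytotoxicity, read by WST assay, tested at 100 uM (a lower number here means less inhibition, a higher number more inhibition at the concentration tested (going by the name of the read-out)), so far:

compound 1 `O=C(Nc1cccc(Oc2ccccn2)c1)C1CCCN(C(=O)c2cc(C(F)(F)F)cc(C(F)(F)F)c2)C1` — 0%
compound 2 `O=C(Nc1cccc(OCCc2ccccn2)c1)C1CCCN(C(=O)c2cc(C(F)(F)F)cc(C(F)(F)F)c2)C1` — 5%
compound 3 `CC(=O)c1cccc(NC(=O)C2CCCN(C(=O)c3cc(C(F)(F)F)cc(C(F)(F)F)c3)C2)c1` — 0%

All three share one core and differ only in the substituent on one aromatic carbon. In this assay compound 3 stands level with compound 1, and together they give the lowest of the three numbers; compound 2 is the furthest away, yet a number 5 percentage points lower from compound 2 to compound 3 (within the scatter). Likewise no change at the digits printed from compound 1 to compound 3 (within the scatter) and a number 5 percentage points higher from compound 1 to compound 2 (within the scatter). So far, then, every exchange at this aromatic carbon has left the read-out within the scatter of a repeated measurement, and no compound has shown inhibition worth the name.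

Compound 4 `CC(C)(C)OC(=O)c1cccc(NC(=O)C2CCCN(C(=O)c3cc(C(F)(F)F)cc(C(F)(F)F)c3)C2)c1` is the next step from compound 3. The change is tert-butoxy in place of methyl on a carbonyl carbon. It sits inside the acetyl group rather than exchanging the whole substituent, so it is a smaller alteration than any of the three measured steps, all of which stayed within the scatter. For the measured compounds named here, no measured step bears directly on a tert-butoxy in this place, but with every step so far flat, no movement beyond the scatter is expected in this assay either: the expected step is a number 2 percentage points higher from compound 3 to compound 4 (within the scatter). Compound 4 is therefore estimated at 2%, within a range from 0% to 14%.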

Compound 4, a percentage reported as inhibition, at one concentration (the size of the read-out at that concentration, not a potency): 0%
The estimate for compound 4 lay 2 percentage points above the measured number; the measured number falls inside the stated range.
By their numbers in this assay, from the lowest: compounds 1, 3, 4 and 2 (each within the scatter of the next).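

Exchanging methyl (1 heavy atom) for tert-butoxy (5 heavy atoms, 1 hydrogen-bond acceptor) on a carbonyl carbon whose other neighbour is an aromatic carbon turns acetyl into tert-butoxycarbonyl, and in this assay this gives no change at the digits printed from compound 3 to compound 4 (within the scatter), showing that a change made within the group, rather than an exchange of the whole substituent, also stays flat. The comparisons with the two pyridine-bearing substituents read the same way, with no change at the digits printed from compound 1 to compound 4 (within the scatter) and a number 5 percentage points lower from compound 2 to compound 4 (within the scatter), so all four substituents on this aromatic carbon now lie within the scatter of one another, and none gives inhibition worth the name. Nothing available explains this flat result, and the numbers alone cannot connect it to any property of the groups.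

Still open, going by these compounds, is whether a carboxylic acid, with hydroxy in place of tert-butoxy on the carbonyl carbon, or an amine or a longer chain on the aromatic carbon would give a different reading in this assay. On these data alone, all four compounds keep the shared core, so the effect of changing any other part of it also remains open.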